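Swapping an ether oxygen for sulfur on a diamino core

The source may report more compounds than this note shows. Statements on the series, on what has been measured and on what is new or still open speak of the compounds shown alone.

Measured compounds:
- compound 1, `Nc1cc(N)c2nc(-c3ccccc3)c(NCc3ccc(F)cc3)nc2c1`: 56200 nM
- compound 2, `COc1ccc(Sc2nc3cc(N)cc(N)c3nc2-c2ccccc2)cc1`: < 100000 nM
- compound 3, `Nc1cc(N)c2nc(-c3ccccc3)c(Oc3ccc(F)cc3)nc2c1`: 44700 nM

All three share one core and differ only in the group hanging from it. In a functional assay on M14 cells (Homo sapiens) for inhibition, read by sulforhodamine B assay, with a stated time of 48 h (a higher number here means a weaker inhibitor of growth, a lower number a stronger inhibitor of growth), compound 3 gives 44700 nM. In this assay compound 1 gives 56200 nM. For compound 2 this assay reports only a limit, < 100000 nM, so no number is available. Among the two numbers, compound 3 has the lowest, and its nearest neighbour is compound 1: the step of a 1.3-fold lower number from compound 1 to compound 3 (0.10 log units; within the scatter) is within the scatter. The step that the limit leaves unreadable from compound 1 to compound 2 and the step that the limit leaves unreadable from compound 2 to compound 3 cannot be sized, since one end is the limit (the limit of < 100000 nM in this assay, at which 1 of the 3 values shown sits).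

Compound 4, `Nc1cc(N)c2nc(-c3ccccc3)c(Sc3ccc(F)cc3)nc2c1`, has not yet been measured in this assay. The change from compound 3 is (4-fluorophenyl)sulfanyl in place of 4-fluorophenoxy on an aromatic carbon. Among the measured compounds shown here, the only readable step, from compound 1 to compound 3, was within the scatter, so the expectation is no step beyond the scatter here either. Compound 4 is therefore expected to give about 45000 nM in this assay, with a range from 18000 nM to 100000 nM, an expected step of a 1.0-fold higher number from compound 3 to compound 4 (0.00 log units; within the scatter).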

Compound 4, concentration for total growth inhibition: 30900 nM
Estimate against measurement, compound 4: 1.5-fold (0.16 log units) above; low and high end bracket the measured number.
By their numbers in this assay, from the lowest: compounds 4, 3 and 1 (each within the scatter of the next).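

In this assay, putting sulfur in place of the ether oxygen, with the 4-fluorophenyl ring kept, gives a 1.4-fold lower number from compound 3 to compound 4 (0.16 log units; within the scatter). Setting the (4-fluorophenyl)sulfanyl group in place of the (4-fluorobenzyl)amino group gives a 1.8-fold lower number from compound 1 to compound 4 (0.26 log units; within the scatter). Neither step leaves the scatter, so with a sulfur link now added to the oxygen and amino links, this position has still shown no readable difference among compounds 1, 3 and 4.

Compound 2 carries only a limit, which is not a number, so the step from fluoro to methoxy on the sulfur-linked ring and the other steps that involve compound 2 cannot be read: the limit of < 100000 nM in this assay, at which 1 of the 4 values shown sits.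

Also open, from the compounds shown here alone, is whether a group of another kind at this position, such as a carboxylic acid or a longer alkyl chain, would give a step beyond the scatter.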